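Hydroxy added to the chlorophenyl of compound 3

A few compounds are considered here, and "the series" means these few. Any claim that something is new, unique, unknown or untested is made for them only; others in the source may bear on it.

Compound 1 `COc1ccc(C(=O)/C=C/c2cccc([N+](=O)[O-])c2)c2c1C=CC(C)(C)O2`: 2830 nM
Compound 2 `COc1ccc(C(=O)/C=C/c2ccc(Cl)cc2)c2c1C=CC(C)(C)O2`: > 10000 nM (a limit)
Compound 3 `COc1ccc(C(=O)/C=C/c2cccc(Cl)c2)c2c1C=CC(C)(C)O2`: > 10000 nM (a limit)

All three were read in a functional assay on HepG2 cells (Homo sapiens) for antiproliferative activity, read by MTT assay, with a stated time of 24 h (a higher number here means a weaker inhibitor, a lower number a stronger inhibitor), and share one core. Compound 3 stands at > 10000 nM as a limit of the assay and not a number. Compound 4 `COc1ccc(C(=O)/C=C/c2cc(Cl)ccc2O)c2c1C=CC(C)(C)O2` carries hydroxy in place of hydrogen on an aromatic carbon and so turns 3-chlorophenyl to 5-chloro-2-hydroxyphenyl.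

Among the compounds with values here, no measured step adds a hydroxy. The nearest ones change the same ring: there is an at least 3.5-fold higher number from compound 1 to compound 3 (0.54 log units; beyond the scatter) and also an at least 3.5-fold higher number from compound 1 to compound 2 (0.54 log units; beyond the scatter), while moving the chloro gives a step that the two limits leave unreadable from compound 2 to compound 3. These steps show that this ring can move the number, but they do not size a hydroxy. At best, a modest step toward a lower number is expected in this assay, and compound 4 may well stay at the limit of > 10000 nM in this assay, at which 2 of the 3 values shown sit. The estimated step is an at least 1.1-fold lower number from compound 3 to compound 4 (0.04 log units; that floor lies within the scatter). Compound 4 is expected near 9000 nM, with an estimated range from 3000 nM to 25000 nM.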

Compound 4, half-maximal inhibitory concentration: 6640 nM
Estimate against measurement, compound 4: 1.4-fold (0.13 log units) above; the range from low to high includes it.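

In this assay, hydroxy in place of hydrogen, ortho to a large group and para to the chloro group, gives the only chloro compound shown that has a number and not a limit, with an at least 1.5-fold lower number from compound 3 to compound 4 (0.17 log units; that floor lies within the scatter) and also an at least 1.5-fold lower number from compound 2 to compound 4 (0.17 log units; that floor lies within the scatter). Going by these compounds, both steps start from limits, so only their floors can be read, and their true size remains unknown. Even with the hydroxy, the chloro series does not reach the nitro compound, as there is a 2.3-fold higher number from compound 1 to compound 4 (0.37 log units; beyond the scatter).

The compounds shown leave open whether an amine or a methoxy at the same place would do what hydroxy does, and whether hydroxy would also lower the number on the 3-nitrophenyl of compound 1. Any reading of this ring also remains bounded by the limits: the limit of > 10000 nM in this assay, at which 2 of the 4 values shown sit.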